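Chain length of the tetrazole side chain

The source may hold more compounds than are shown below. What is called first, only, known or untested is meant among the compounds shown, and "the series" means these compounds.

Measured so far in an assay on isolated protein for binding affinity to leukotriene B4 receptor 1 (Homo sapiens), tested at 1 uM; a higher number here means more inhibition at the concentration tested (going by the name of the read-out), a lower number less inhibition:
- compound 1 `CCc1cc(C(C)=O)c(O)cc1OCCCCCC[S+](C)[O-]` gives 50%
- compound 2 `CCc1cc(C(C)=O)c(O)cc1OCCCCc1nnn[nH]1` gives 19%

Going by the values given here, compound 2 stands lowest of the two numbers; its only neighbour is compound 1, which lies beyond the scatter above it. Among the compounds with values here, the single measured step, a number 31 percentage points lower from compound 1 to compound 2 (beyond the scatter), exchanges a group with no ring for the five-membered aromatic ring with four hetero atoms, and in the same step the ring comes to sit closer to the aromatic oxygen than the replaced group did.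

Compound 3 `CCc1cc(C(C)=O)c(O)cc1OCCCCCCc1nnn[nH]1` differs from compound 2 by 2-(1H-tetrazol-5-yl)ethyl in place of 1H-tetrazol-5-yl on a saturated chain carbon, four bonds along the chain from an oxygen on an aromatic ring. Within the data shown here, no measured pair isolates this change: the step from compound 1 to compound 2 alters both the group and its distance along the chain, so the part owed to distance alone cannot be read from it. The longer compound 1 gives the higher number, but it carries no ring, so this is weak guidance. The expectation is a modest upward step, a number 11 percentage points higher from compound 2 to compound 3 (beyond the scatter), with wide uncertainty. Compound 3 is estimated at 30%, in the range 10% to 55%.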

Compound 3, a percentage reported as inhibition, at one concentration (the size of the read-out at that concentration, not a potency): 60%
Beside the measured number, compound 3's estimate is 30 percentage points below it; measured number above the stated range.
By their numbers in this assay, from the lowest: compound 2; then compounds 1 and 3 (each within the scatter of the next).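

In this assay, the ring now stays constant while the chain changes: 2-(1H-tetrazol-5-yl)ethyl in place of 1H-tetrazol-5-yl, on a saturated chain carbon four bonds along the chain from an oxygen on an aromatic ring, gives a number 41 percentage points higher from compound 2 to compound 3 (beyond the scatter), so chain length alone moves this read-out by a large amount, which the earlier step, mixing group and distance, could not separate. With the two end groups compared six bonds along the chain from that oxygen, the result is a number 10 percentage points higher from compound 1 to compound 3 (within the scatter), so the low number of compound 2 does not follow from the presence of the tetrazole ring as such. No supporting data accompany these numbers to account for the effect of the chain.

With only two tetrazole chain lengths shown, it remains open whether a longer chain, such as one ending in 4-(1H-tetrazol-5-yl)butyl at the same place, would raise, hold or lower the number. From the compounds shown here alone, it is equally open how a carboxylic acid at the end of the same chain would compare with the tetrazole of compound 3.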